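The compounds below may be only part of what the source reports. "The series", "measured", "known", "first", "only" and "open" are said of these compounds alone.

Working notes on the series. In an assay on isolated protein for activation of cGMP-dependent protein kinase 1 (Homo sapiens), read by ADP-Glo, with stated times of 30 min and 2 h (a lower number here means that less compound is needed, a higher number that more compound is needed for the effect), compound 1 `O=C(O)c1ccc(CN2CCC[C@H](O[C@H](CO)c3cc(Cl)cc(Cl)c3)[C@@H]2c2ccccc2)cc1` gives 77000 nM. Compound 2 `COC(=O)Nc1cc(C(=O)O)ccc1CN1CCC[C@H](O[C@H](CO)c2cc(Cl)cc(Cl)c2)[C@@H]1c1ccccc1` carries a (methoxycarbonyl)amino group on the carboxy-bearing ring and gives 69000 nM in this assay; the step of a 1.1-fold lower number from compound 1 to compound 2 (0.05 log units; within the scatter) is within the scatter. Compound 3 `O=C(O)c1ccc(CN2CCC[C@H](O[C@H](CO)c3cc(Cl)cc(Cl)c3)[C@@H]2c2ccccc2)c([N+](=O)[O-])c1` carries a nitro group at the same position and gives 13000 nM in this assay, the lowest of the three numbers, with a 5.9-fold lower number from compound 1 to compound 3 (0.77 log units; beyond the scatter) and a 5.3-fold lower number from compound 2 to compound 3 (0.72 log units; beyond the scatter).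

Compound 4 `Nc1cc(C(=O)O)ccc1CN1CCC[C@H](O[C@H](CO)c2cc(Cl)cc(Cl)c2)[C@@H]1c1ccccc1` differs from compound 3 by amino in place of nitro on an aromatic carbon. Among the measured compounds shown here, no measured step covers an amino group at this position; the two steps that bear on it both lead into the nitro compound and show that either hydrogen, as in a 5.9-fold lower number from compound 1 to compound 3 (0.77 log units; beyond the scatter), or (methoxycarbonyl)amino, as in a 5.3-fold lower number from compound 2 to compound 3 (0.72 log units; beyond the scatter), gives a modestly higher number than nitro. Removing the nitro group in favour of a third substituent is therefore expected to move the number back upward in this assay, most likely by a modest step, since the two non-nitro compounds 1 and 2 sit close together. For compound 4 the expected step is a 3.1-fold higher number from compound 3 to compound 4 (0.49 log units; beyond the scatter). Compound 4 is thus estimated at 40000 nM in this assay, with a range from 15000 nM to 100000 nM.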

Compound 4, half-maximal effective concentration in the cGMP-dependent protein kinase 1 assay: 168000 nM
Compound 4: the middle estimate sits 4.2-fold (0.62 log units) below what was measured; the whole stated range lies below it.
By their numbers in the cGMP-dependent protein kinase 1 assay, from the lowest: compound 3; then compounds 2 and 1 (each within the scatter of the next); then compound 4.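

Among the compounds shown here, at this place, on an aromatic carbon ortho to a large group, the exchange of nitro for amino in the cGMP-dependent protein kinase 1 assay is the largest step so far (a 13-fold higher number from compound 3 to compound 4 (1.11 log units; beyond the scatter)), and it exceeds both earlier steps into the nitro compound; compound 3 gives 13000 nM and compound 4 gives 168000 nM. The amino group also stands apart from the other two non-nitro substituents in the cGMP-dependent protein kinase 1 assay, both against hydrogen (a 2.2-fold higher number from compound 1 to compound 4 (0.34 log units; beyond the scatter)) and against its own methoxycarbonyl-capped form (a 2.4-fold higher number from compound 2 to compound 4 (0.39 log units; beyond the scatter)), so this position moves the number in both directions from hydrogen, down with nitro and up with amino. In a physicochemical assay for solubility, at pH 2 (on this read-out lower numbers stand for lower solubility and higher numbers for higher solubility), compound 3 gives 172000 nM and compound 4 gives 126000 nM. For the compounds shown here, the same exchange in the physicochemical assay stays within the scatter (a 1.4-fold lower number from compound 3 to compound 4 (0.14 log units; within the scatter)), so the large step in the cGMP-dependent protein kinase 1 assay has no counterpart on that read-out.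

The compounds shown leave open whether a nitrile or a trifluoromethyl group at this place follows nitro, and whether a methylamino or acetylamino group follows amino or the methoxycarbonyl-capped form. No measurement at hand accounts for the gap between nitro and amino at this position.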